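Trading a Chlorophenyl for a Nitrophenyl: Compound 4 Expected

The source may hold more compounds than are shown below. What is called first, only, known or untested is meant among the compounds shown, and "the series" means these compounds.

The measured compounds:
- Compound 1 `Clc1ccccc1CSc1nnc(-c2ccncc2)n1-c1ccccc1`; in a functional assay on HepG2 cells (Homo sapiens) for inhibition, read by MTT assay, with a stated time of 48 h (on this read-out lower numbers stand for stronger inhibition and higher numbers for weaker inhibition), compound 1 gives 15700 nM
- Compound 2 `Clc1cccc(CSc2nnc(-c3ccncc3)n2-c2ccccc2)c1`; in this assay compound 2 gives 11200 nM
- Compound 3 `Brc1ccc(CSc2nnc(-c3ccncc3)n2-c2ccccc2)cc1`; in this assay compound 3 gives 12900 nM

Compound 2 has the lowest of the three numbers shown, but its steps to the others are small: a 1.4-fold lower number from compound 1 to compound 2 (0.15 log units; within the scatter) and, read the other way, a 1.2-fold higher number from compound 2 to compound 3 (0.06 log units; within the scatter), both within the scatter, as is a 1.2-fold lower number from compound 1 to compound 3 (0.09 log units; within the scatter). The three compounds therefore sit together, and none can be called more or less active than another.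

Compound 4 `O=[N+]([O-])c1ccc(CSc2nnc(-c3ccncc3)n2-c2ccccc2)cc1` is not yet measured. The change from compound 2 is 4-nitrophenyl in place of 3-chlorophenyl on a saturated chain carbon bound to a sulfur. Every measured step concerns the same place on the shared core, each exchanging one halogenated phenyl for another, and none moved the number beyond the scatter. Among the measured compounds shown here, no measured step brings in a nitrophenyl, so the data give no direct guide for this group; what they show is that variation at this place has so far been quiet.

The step from compound 2 to compound 4 in this assay is therefore expected to be small, a 1.1-fold higher number from compound 2 to compound 4 (0.03 log units; within the scatter), in no particular direction. Compound 4 is estimated at 12000 nM, within a range of 5000 nM to 30000 nM.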

Compound 4, half-maximal inhibitory concentration: > 50000 nM
Compound 4: no number, only a limit; the forecaster's own chance of this, stated with the estimate: 10%; middle value at least 4.1-fold (0.61 log units) away from the limit.
By their numbers in this assay, from the lowest: compounds 2, 3 and 1 (each within the scatter of the next). At a limit, above all of these: compound 4.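

Compound 4 shows that this place on the shared core is not indifferent to what it carries, since 4-nitrophenyl in place of 3-chlorophenyl gives an at least 4.4-fold higher number from compound 2 to compound 4 (0.64 log units; beyond the scatter), and nitro in place of bromo on an aromatic carbon gives an at least 3.8-fold higher number from compound 3 to compound 4 (0.58 log units; beyond the scatter). With 4-nitrophenyl in place of 2-chlorophenyl the result is an at least 3.1-fold higher number from compound 1 to compound 4 (0.50 log units; beyond the scatter), so all three steps into compound 4 lie beyond the scatter and point towards weaker inhibition, while the steps among compound 1, compound 2 and compound 3 stayed within it. Compound 4 gives only a limit in this assay, not a number, and each of these steps is therefore a lower bound whose full size stays unknown: the limit of > 50000 nM in this assay, at which 1 of the 4 values shown sits.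

The compounds shown leave open whether the nitro group alone goes with this loss, as a single nitro compound cannot say how a phenyl carrying an amine, a methoxy group or a carboxylic acid would behave at this place. Also open, from the compounds shown here alone, is whether a longer chain between the sulfur and the 4-nitrophenyl would give the same result.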